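From a Short Acyl Chain to a Chlorophenyl Carbonyl

The compounds below may be only part of what the source reports. "The series", "measured", "known", "first", "only" and "open" are said of these compounds alone.

Three compounds share one core and differ only in the group carried on the carbonyl carbon of the ring amide. Compound 1 `CCCC(=O)N1c2ccccc2CCC1C(=O)Nc1ccccc1C(F)(F)F` carries a butanoyl group; in a functional assay on NUGC-3 cells (Homo sapiens) for cytotoxicity, read by sulforhodamine B assay, with a stated time of 72 h (on this read-out lower numbers stand for stronger inhibition of growth and higher numbers for weaker inhibition of growth), compound 1 gives only a limit of the assay, > 70000 nM, and no number. Compound 2 `CCCCCCCCC(=O)N1c2ccccc2CCC1C(=O)Nc1ccccc1C(F)(F)F` carries a nonanoyl group, and in this assay compound 2 gives 6180 nM. Compound 3 `CCC(=O)N1c2ccccc2CCC1C(=O)Nc1ccccc1C(F)(F)F` carries a propanoyl group; in this assay compound 3 also gives only a limit, > 80000 nM, so of the three values shown it stands at a limit rather than at a number. The measured steps run an at least 11-fold lower number from compound 1 to compound 2 (1.05 log units; beyond the scatter) and an at least 12-fold higher number from compound 2 to compound 3 (1.11 log units; beyond the scatter), while a step that the two limits leave unreadable from compound 1 to compound 3. Compound 4 `O=C(Nc1ccccc1C(F)(F)F)C1CCc2ccccc2N1C(=O)c1cccc(Cl)c1` differs from compound 3 by 3-chlorophenyl in place of ethyl on a carbonyl carbon, on a carbonyl carbon whose other neighbours are an amide-type nitrogen in a ring. The two readable steps both point the same way: a larger group on this carbonyl carbon goes with a far lower number, and compound 4 brings a 3-chlorophenyl group with seven heavy atoms in place of ethyl. A large downward step is therefore expected, an at least 10-fold lower number from compound 3 to compound 4 (1.00 log units; beyond the scatter), and compound 4 is estimated at 8000 nM, within a range from 2000 nM to 40000 nM.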

Compound 4, concentration for 50% growth inhibition: 754 nM
Compound 4: the middle estimate sits 11-fold (1.03 log units) above what was measured, outside the stated range (below it).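

The earlier compounds tied a lower number on this carbonyl carbon only to a longer chain, but compound 4 shows that 3-chlorophenyl can take the place of a chain altogether and go further than the longest chain shown, with an 8.2-fold lower number from compound 2 to compound 4 (0.91 log units; beyond the scatter) in this assay. Against the two short chains the change is far larger, with an at least 100-fold lower number from compound 3 to compound 4 (2.02 log units; beyond the scatter) and an at least 92-fold lower number from compound 1 to compound 4 (1.96 log units; beyond the scatter). Compound 3 stands at a limit of the assay rather than at a number, so the step from it marks only a floor and not a true size: the limit of > 80000 nM in this assay, at which 1 of the 4 values shown sits.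

The compounds shown leave open whether the aromatic ring alone accounts for this change or whether the chlorine is needed, which a plain phenyl group on the same carbonyl carbon would separate. They also leave open whether a saturated ring such as cyclohexyl, or a chain longer than nonanoyl, would reach the level of compound 4.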